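Series notes: amide side-chain amines on the shared core

The compounds below may be only part of what the source reports. "The series", "measured", "known", "first", "only" and "open" are said of these compounds alone.

Among the measured compounds shown here, compound 2 `NS(=O)(=O)Oc1ccc2c(c1)CN(C(=O)c1cccc(N3CCCCC3)c1)CC2` gives 11.9% in an assay on HEK293 cells for inhibition of Steryl-sulfatase (Homo sapiens), tested at 1 uM (a lower number here means a weaker effect, a higher number a stronger effect of the compound at the concentration tested), the lower of the two numbers measured so far. Compound 1 `CCN(Cc1ccc(F)cc1)c1cccc(C(=O)N2CCc3ccc(OS(N)(=O)=O)cc3C2)c1` gives 66.5%. For the measured compounds named here, the only step known is a number 54.6 percentage points lower from compound 1 to compound 2 (beyond the scatter). Compound 3 `CN(CCCN1CCCCC1)c1cccc(C(=O)N2CCc3ccc(OS(N)(=O)=O)cc3C2)c1` carries methyl(3-(piperidin-1-yl)propyl)amino in place of piperidin-1-yl on an aromatic carbon. Going by the values given here, the one step bearing on it shows that an open-chain tertiary amino on this aromatic carbon ran far stronger than the ring amine, so a step upward from compound 2 is expected, though smaller than the drop seen from compound 1 to compound 2. For compound 3 the expected step is a number 23.1 percentage points higher from compound 2 to compound 3 (beyond the scatter). Compound 3 is estimated at 35%, within 10% to 65%.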

Compound 3, a percentage reported as inhibition, at one concentration (the size of the read-out at that concentration, not a potency): 30.6%
For compound 3 the middle estimate is 4.4 percentage points above the measured one, and the stated range covers the measured number.
By their numbers in this assay, from the lowest: compound 2; then compound 3; then compound 1.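

Putting methyl(3-(piperidin-1-yl)propyl)amino in place of piperidin-1-yl on this aromatic carbon gives a number 18.7 percentage points higher from compound 2 to compound 3 (beyond the scatter), while the same group in place of ethyl(4-fluorobenzyl)amino gives a number 35.9 percentage points lower from compound 1 to compound 3 (beyond the scatter), both in this assay. An open-chain amino group on this carbon therefore does not by itself set the level: the two such groups shown stand well apart, and the ring amine stays lowest. No measurement at hand accounts for either step. Which part of ethyl(4-fluorobenzyl)amino carries the higher level remains open. A plain benzyl in place of 4-fluorobenzyl, or a morpholine in place of the chain's piperidine, would test this.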